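This account rests on a few compounds, and the source may have more. Where it says the series, first, only, none or still open, it means among the compounds named here.

Measured so far in a functional assay on HepG2 cells (Homo sapiens) for inhibition, read by MTT assay, with a stated time of 72 h; a higher number here means a weaker inhibitor, a lower number a stronger inhibitor:

Compound 1 `Cc1ccccc1-n1cc(COc2cccc(NC(=O)Nc3ccc(Cl)c(C(F)(F)F)c3)c2)nn1` gives 3440 nM.
Compound 2 `CC(C)c1cccc(-n2cc(COc3cccc(NC(=O)Nc4ccc(Cl)c(C(F)(F)F)c4)c3)nn2)c1` gives 3250 nM.

Both compounds share the same urea-linked core and differ only in the group carried on an aromatic nitrogen. Compound 2 holds the lowest of the two numbers in this assay, but its nearest neighbour, compound 1, sits within the scatter of it, so the two cannot be told apart. For the measured compounds named here, the single measured step, a 1.1-fold lower number from compound 1 to compound 2 (0.02 log units; within the scatter), went with 3-isopropylphenyl in place of 2-methylphenyl on an aromatic nitrogen, and it shows that this end of the molecule took a change of group without a shift beyond the scatter.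

Compound 3 `O=C(Nc1cccc(OCc2cn(-c3cccc(F)c3)nn2)c1)Nc1ccc(Cl)c(C(F)(F)F)c1` has not yet been measured. It differs from compound 2 by fluoro in place of isopropyl on an aromatic carbon, on an aromatic carbon of a six-membered aromatic ring of carbon only. Going by the values given here, the one step that bears on it, a 1.1-fold lower number from compound 1 to compound 2 (0.02 log units; within the scatter), was flat, so the change from compound 2 to compound 3 is expected to fall within the scatter as well: a 1.1-fold higher number from compound 2 to compound 3 (0.03 log units; within the scatter) is the estimate. Compound 3 is therefore estimated at 3500 nM, with a range from 1500 nM to 8000 nM.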

Compound 3, half-maximal inhibitory concentration: 2120 nM
Compound 3: the middle estimate sits 1.7-fold (0.22 log units) above what was measured; low and high end bracket the measured number.
By their numbers in this assay, from the lowest: compounds 3, 2 and 1 (each within the scatter of the next).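

In this assay, the step of a 1.5-fold lower number from compound 2 to compound 3 (0.19 log units; within the scatter) swaps isopropyl, with 3 heavy atoms, for fluoro, with 1 heavy atom, on an aromatic carbon meta to a large group. This position has therefore now taken a much smaller group without a shift beyond the scatter, which the earlier step between two carbon-only substituents could not show. The step of a 1.6-fold lower number from compound 1 to compound 3 (0.21 log units; within the scatter), with 3-fluorophenyl in place of 2-methylphenyl on an aromatic nitrogen, also stays within the scatter, so the three groups seen at this end of the molecule cannot be told apart, and nothing at hand explains this flat result.

The compounds shown leave open whether this position would respond to a group of a different kind, such as an amine or a carboxylic acid. They also leave open whether a longer chain on the same aromatic carbon would move the number in this assay beyond the scatter.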